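Lengthening the hydroxy chain of compound 2

A few compounds are considered here, and "the series" means these few. Any claim that something is new, unique, unknown or untested is made for them only; others in the source may bear on it.

Measured so far:
- compound 1 `NS(=O)(=O)c1ccc(S(=O)(=O)CCCO)cc1` (8.98)
- compound 2 `NS(=O)(=O)c1ccc(SCCO)c(F)c1` (9.76)

Working notes on a physicochemical assay for acid dissociation, follow. Compound 2 (9.76) stands higher of the two numbers available, and its nearest neighbour, compound 1 (8.98), lies lower by a gap beyond the usual scatter. Among the compounds with values here, these two compounds differ in more than one place, so their gap gives no size for any single change, and no step between measured compounds is available.

The next compound is compound 3 `NS(=O)(=O)c1ccc(SCCCCO)c(F)c1`, still to be measured in this assay. The change from compound 2 is 2-hydroxyethyl in place of hydroxy on a saturated chain carbon, two bonds along the chain from a sulfur and it falls on a saturated chain carbon, two bonds along the chain from a sulfur. The shared core stays as it is, and the chain still ends in a hydroxy group.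

With only compound 2 (9.76) as the close reference, no shift beyond the scatter is expected. The estimated step is a number 0.04 log units higher from compound 2 to compound 3 (within the scatter) and it carries no firm direction. For compound 3 the estimate is 9.8 with an expected range from 9.5 to 10.1 in this measure.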

Compound 3, acid dissociation constant: 9.82
Estimate against measurement, compound 3: 0.02 log units below; the range from low to high includes it.
By their numbers in this assay, from the lowest: compound 1; then compounds 2 and 3 (each within the scatter of the next).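

In this assay, 2-hydroxyethyl in place of hydroxy on a saturated chain carbon, two bonds along the chain from a sulfur, gives a number 0.06 log units higher from compound 2 to compound 3 (within the scatter). Within the data shown here, this is the first step between compounds that differ in one place, so the chain change now has a size, which the gap between compound 1 and compound 2 could not provide. At this position, the added length leaves compound 2 and compound 3 indistinguishable in this read-out, and no supporting data bear on the reason for this result.

The compounds shown leave open whether the same holds for a longer chain than the 4-hydroxybutyl of compound 3, or for a chain ending in an amine or a carboxylic acid rather than a hydroxy group. Also open, as far as these compounds go, is whether this change would give a similar step on the core of compound 1, which differs from compound 2 in more than one place.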